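The source may report more compounds than this note shows. Statements on the series, on what has been measured and on what is new or still open speak of the compounds shown alone.

Measured so far:
- compound 1 `CC(=O)N1N=C(c2cc(O)c(O)c([N+](=O)[O-])c2)CC1c1ccco1`: 77400 nM
- compound 2 `O=C(/C=C/c1cccc(O)c1)c1cc(O)c(O)c([N+](=O)[O-])c1`: 55800 nM

Both compounds were run in an assay on isolated protein for inhibition of Amine oxidase [flavin-containing] B (Homo sapiens), read by fluorescence; on this read-out lower numbers stand for stronger inhibition and higher numbers for weaker inhibition. Compound 1 gives 77400 nM and compound 2 gives 55800 nM; the two numbers lie within the scatter of each other, so the data show no difference between compound 1 and compound 2 in this assay. Compound 1 is the only one of the two that shares its core with the next compound, so it is the reference point here.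

Compound 3 `CC(=O)N1N=C(c2cc(O)c(O)c([N+](=O)[O-])c2)CC1c1nccs1` is not yet measured. It differs from compound 1 in one place: 1,3-thiazol-2-yl in place of furan-2-yl on a saturated ring carbon. Among the compounds with values here, no step between two measured compounds resembles this change, so there is nothing in the data to set its size or direction. The change swaps one five-membered aromatic ring for another of the same atom count, and both measured compounds sit in the same weak range. The expectation is therefore a step of about none beyond the scatter, in either direction: an estimated step of a 1.1-fold lower number from compound 1 to compound 3 (0.04 log units; within the scatter). Compound 3 is expected to give about 70000 nM in this assay, with a plausible range from 25000 nM to 200000 nM.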

Compound 3, half-maximal inhibitory concentration: 68200 nM
For compound 3 the middle estimate is 1.0-fold (0.01 log units) above the measured one; the measured number falls inside the stated range.
By their numbers in this assay, from the lowest: compounds 2, 3 and 1 (each within the scatter of the next).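

On the saturated ring carbon of the shared core, this assay gives for 1,3-thiazol-2-yl in place of furan-2-yl a 1.1-fold lower number from compound 1 to compound 3 (0.05 log units; within the scatter), the only step at this position among the compounds shown. The exchange of a five-membered aromatic ring with 1 hetero atom for one with 2 hetero atoms, with sulfur and nitrogen entering and oxygen leaving and the hydrogen-bond acceptor count going from 1 to 2, does not separate compound 1 from compound 3 on this read-out, so these two rings can be treated as equivalent here and in this assay alone. No supporting measurement bears on why the two rings read alike.

As far as these compounds go, both groups at this position are five-membered aromatic rings, so it remains open whether a primary amine, a carboxylic acid or a longer alkyl chain on this carbon would give a number outside the range of compound 1 and compound 3. From the compounds shown here alone, the acetyl group is the same in compound 1 and compound 3, so whether this position responds differently with a propanoyl group in its place also remains open.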